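The compounds below may be only part of what the source reports. "The series", "measured", "known", "first", "only" and "open" are said of these compounds alone.

The series shares one core, carried in `Cc1ccc2nc([C@H](CC3CCNCC3)N3C(=O)CN(c4ccc(Oc5ccccc5)cc4)C3=O)n(C)c2c1` as compound 1, and is read in an assay on cells for antagonist activity at Bile acid receptor (Homo sapiens), read by a luciferase reporter, with a stated time of 24 h; a lower number here means a stronger inhibitor, a higher number a weaker inhibitor. Compound 1 gives 4510 nM. Compound 2, `Cc1ccc2nc([C@H](CC3CCN(C(=O)C(C)C)CC3)N3C(=O)CN(c4ccc(Oc5ccccc5)cc4)C3=O)n(C)c2c1`, carries an isopropylcarbonyl in place of hydrogen on the amine nitrogen in the ring; for compound 2 the value is a limit of the assay, < 0.001 nM, not a number, as the limit of < 0.001 nM in this assay, at which 1 of the 3 values shown sits, records. Compound 3, `Cc1ccc2nc([C@H](CC3CCN(C(=O)C4CCCC4)CC3)N3C(=O)CN(c4ccc(Oc5ccccc5)cc4)C3=O)n(C)c2c1`, carries a cyclopentylcarbonyl there instead and gives 0.006 nM. The steps are an at least 4500000-fold lower number from compound 1 to compound 2 (6.65 log units; beyond the scatter), a 750000-fold lower number from compound 1 to compound 3 (5.88 log units; beyond the scatter) and an at least 6.0-fold higher number from compound 2 to compound 3 (0.77 log units; beyond the scatter), and all of them concern the group on the amine nitrogen in the ring.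

Compound 4, `CC(C)C(=O)N1CCC(C[C@@H](c2nc3ccccc3n2C)N2C(=O)CN(c3ccc(Oc4ccccc4)cc3)C2=O)CC1`, differs from compound 2 at a different place: hydrogen in place of methyl on an aromatic carbon. Within the data shown here, none of the measured steps touches that aromatic carbon, so no step in this set speaks directly to the change. Compound 2 stands at the limit of this assay, and the change to compound 4 is a small one, so compound 4 is expected to stay at or near that limit, with a step of a number no lower from compound 2 to compound 4 (the limit leaves the size open) expected, not beyond the scatter. The estimate for compound 4 is 0.001 nM, expected between 0.0001 nM and 0.01 nM, and it is expected that this assay may again report only a limit for compound 4.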

Compound 4, half-maximal inhibitory concentration: < 0.001 nM
Compound 4: a limit, no number; the forecaster's own chance of this, stated with the estimate: 60%; the middle value lies on the limit itself.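

In this assay compound 4 gives < 0.001 nM, which is a limit and not a number. Compound 2 also stands only at a limit, so no step can be read between compound 2 and compound 4. The compounds shown leave open whether hydrogen in place of methyl on that aromatic carbon changes the number in this assay at all.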